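The source may hold more compounds than are shown below. What is called first, only, known or untested is meant among the compounds shown, and "the series" means these compounds.

Measured compounds:
- compound 1, `CCCCN(CCCC)c1ccc(C(=O)C2CC2c2ccc(Cl)cc2)cc1`, in an ADME assay on Vero cells (Chlorocebus sabaeus) for cytotoxicity, with a stated time of 72 h (a lower number here means that less compound is tolerated, a higher number that more compound is tolerated), gives 431 ug/mL
- compound 2, `O=C(c1ccc(N2CCCCC2)cc1)C1CC1c1ccc(Cl)cc1`, in this assay gives 284 ug/mL

For the measured compounds named here, compound 2 has the lowest of the two numbers measured so far in this assay; its nearest neighbour is compound 1, and the only measured step, a 1.5-fold lower number from compound 1 to compound 2 (0.18 log units; within the scatter), is within the scatter, so the two compounds cannot be ordered on these data.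

The next compound, compound 3, `O=C(c1ccc(NCCn2cncn2)cc1)C1CC1c1ccc(Cl)cc1`, differs from compound 2 in one place: (2-(1H-1,2,4-triazol-1-yl)ethyl)amino in place of piperidin-1-yl on an aromatic carbon. Going by the values given here, no measured step bears directly on this exchange; the one step available, from compound 1 to compound 2, concerns a different pair of groups on the same aromatic carbon and was itself within the scatter. With nothing in the series pointing in a direction, the expectation for this assay is a step of a 1.1-fold higher number from compound 2 to compound 3 (0.05 log units; within the scatter), that is no change beyond the scatter, with a wide range to allow for the untested group. Compound 3 is therefore estimated at 320 ug/mL, between 150 ug/mL and 700 ug/mL.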

Compound 3, half-maximal cytotoxic concentration: 39.9 ug/mL
Compound 3: the middle estimate sits 8.0-fold (0.90 log units) above what was measured; the whole stated range lies above it.
By their numbers in this assay, from the lowest: compound 3; then compounds 2 and 1 (each within the scatter of the next).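

For the compounds shown here, the aromatic carbon para to a large group is not indifferent to what it carries: in this assay there is a 7.1-fold lower number from compound 2 to compound 3 (0.85 log units; beyond the scatter) and also an 11-fold lower number from compound 1 to compound 3 (1.03 log units; beyond the scatter) while the exchange between the two dialkylated amines stayed within the scatter, with a 1.5-fold lower number from compound 1 to compound 2 (0.18 log units; within the scatter) as the only earlier step. The entering (2-(1H-1,2,4-triazol-1-yl)ethyl)amino group differs from piperidin-1-yl in several ways at once, bringing a five-membered aromatic ring with 3 hetero atoms and 1 hydrogen-bond donor in place of a six-membered non-aromatic ring with 0 hydrogen-bond donors, so the step belongs to the whole group and not to any one of these features. No evidence is available that explains this step.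

As far as these compounds go, whether the step follows the amine hydrogen, the triazole or the ethyl chain stays open, and a plain ethylamino group, a morpholin-4-yl ring or an imidazole on the same chain would each separate these parts. Also open, from the compounds shown here alone, is whether a longer chain to the triazole stays with compound 3 or returns towards compound 2.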